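Removing the phosphate group from a potent antiproliferative sulfone

The compounds below may be only part of what the source reports. "The series", "measured", "known", "first", "only" and "open" are said of these compounds alone.

For the measured compounds named here, compound 1, with the structure `COc1cc(OC)c(/C=C/S(=O)(=O)Cc2ccc(OC)c(OP(=O)(O)O)c2)c(OC)c1`, is the stronger of the two compounds measured so far. In a functional assay on H157 cells (Homo sapiens) for antiproliferative activity, read by trypan blue exclusion (on this read-out lower numbers stand for stronger inhibition and higher numbers for weaker inhibition), compound 1 gives 7 nM. Going by the values given here, the only other measured compound, compound 2 with the structure `COc1ccc(CS(=O)(=O)/C=C/c2ccc(F)cc2OC)cc1`, gives 20000 nM in this assay, which is far weaker, though its structure differs from compound 1 in several places at once, so no single change can be read from that pair.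

Compound 3, with the structure `COc1ccc(CS(=O)(=O)/C=C/c2c(OC)cc(OC)cc2OC)cc1`, differs from compound 1 in just one place: a hydrogen atom in place of a group of 5 heavy atoms (4 oxygen, 1 phosphorus; no ring), on an aromatic carbon. The change sits ortho to a methoxy group and meta to a large group, on the aromatic carbon that carried the phosphate.

Among the compounds with values here, no measured pair shows what this particular change does, so the expectation rests on compound 1 alone. The step from compound 1 to compound 3 is expected to be modest, with the number for compound 3 likely drifting somewhat higher, around a 2.9-fold higher number from compound 1 to compound 3 (0.46 log units; beyond the scatter). Compound 3 is therefore estimated at 20 nM, within a range from 3 nM to 150 nM.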

Compound 3, half-maximal inhibitory concentration: 30 nM
Beside the measured number, compound 3's estimate is 1.5-fold (0.18 log units) below it, and the stated range covers the measured number.
By their numbers in this assay, from the lowest: compound 1; then compound 3; then compound 2.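

In this assay, replacing the phosphorus-containing group with hydrogen gives a 4.3-fold higher number from compound 1 to compound 3 (0.63 log units; beyond the scatter), so this change is modest but still beyond the usual scatter of repeat measurements. The large group on this aromatic carbon, ortho to a methoxy group, is therefore not essential for strong inhibition in these cells: compound 3, with only a hydrogen atom there, still gives 30 nM. Compound 1 keeps the lower number, so the group does add a measurable gain, but the data offer no explanation for that gain.

The compounds shown leave open what other groups on this same carbon would do: a hydroxyl group, an amine or a carboxylic acid might give a number close to that of compound 1, close to that of compound 3, or different from both. For the compounds shown here, they also leave open whether the same replacement would produce a step of similar size on a different core, since this pair is the only one-place comparison available so far.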